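A Shorter Unsaturated Chain on the Amide Carbonyl

The source may report more compounds than this note shows. Statements on the series, on what has been measured and on what is new or still open speak of the compounds shown alone.

Compound 2, `CCC(=O)N(Cc1ccc(OC)c(O)c1)c1cc(OC)c(OC)c(OC)c1`, holds the second highest of three numbers in a functional assay on KYSE-450 cells (Homo sapiens) for inhibition, read by MTT assay, with a stated time of 48 h (on this read-out higher numbers stand for weaker inhibition and lower numbers for stronger inhibition), where compound 2 gives 98 nM. Compound 1, `CCC/C=C/C(=O)N(Cc1ccc(OC)c(O)c1)c1cc(OC)c(OC)c(OC)c1`, gives 57 nM, and compound 3, `CCCCC(=O)N(Cc1ccc(OC)c(O)c1)c1cc(OC)c(OC)c(OC)c1`, gives 300 nM. Compound 4, `C/C=C/C(=O)N(Cc1ccc(OC)c(O)c1)c1cc(OC)c(OC)c(OC)c1`, differs from compound 2 in one place: prop-1-en-1-yl in place of ethyl on a carbonyl carbon. The closest guide is a 1.7-fold higher number from compound 1 to compound 2 (0.24 log units; within the scatter), a step that likewise trades an unsaturated chain for a saturated one on a carbonyl carbon. The other steps, a 5.3-fold higher number from compound 1 to compound 3 (0.72 log units; beyond the scatter) and a 3.1-fold higher number from compound 2 to compound 3 (0.49 log units; beyond the scatter), show that the longer saturated chain gave a modestly higher number. For compound 4 the expected step is therefore small, leaning toward a lower number, a 1.4-fold lower number from compound 2 to compound 4 (0.15 log units; within the scatter). Compound 4 is estimated at 70 nM, with a range from 35 nM to 140 nM.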

Compound 4, half-maximal inhibitory concentration: 67 nM
For compound 4 the middle estimate is 1.0-fold (0.02 log units) above the measured one; low and high end bracket the measured number.
By their numbers in this assay, from the lowest: compounds 1, 4 and 2 (each within the scatter of the next); then compound 3.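

With prop-1-en-1-yl on the carbonyl carbon, the number stays close to that of the ethyl chain, a 1.5-fold lower number from compound 2 to compound 4 (0.17 log units; within the scatter), and also to that of the longer unsaturated chain, a 1.2-fold higher number from compound 1 to compound 4 (0.07 log units; within the scatter). The butyl chain stands clearly apart, a 4.5-fold lower number from compound 3 to compound 4 (0.65 log units; beyond the scatter). Adding the same two carbons therefore has a different outcome on the saturated and unsaturated chains: the same change on two cores in this assay, a 3.1-fold higher number (0.49 log units; beyond the scatter) from compound 2 to compound 3 and a 1.2-fold lower number (0.07 log units; within the scatter) from compound 4 to compound 1, 3.6-fold (0.56 log units) apart, beyond the scatter of two such steps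

Going by these compounds, how a propyl or a pentyl chain, the saturated counterparts of the two unsaturated chains, would compare remains open. Until then, the contribution of the double bond cannot be separated from that of chain length.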